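This account rests on a few compounds, and the source may have more. Where it says the series, first, only, none or still open, it means among the compounds named here.

Working notes on the series. In an assay on cells for antagonist activity at transient receptor potential cation channel subfamily V member 1 (Homo sapiens), read by FLIPR and calcium flux, with a stated time of 6 min (a lower number here means a stronger inhibitor, a higher number a weaker inhibitor), compound 1 `CC(C)Oc1nc(C(C)(C)C)ccc1CNC(=O)C(C)c1ccc(NS(C)(=O)=O)c(F)c1` gives 2.3 nM, compound 2 `CCCCSc1nc(C(C)(C)C)ccc1CNC(=O)C(C)c1ccc(NS(C)(=O)=O)c(F)c1` gives 3.2 nM, and compound 3 `CC(C(=O)NCc1ccc(C(C)(C)C)cc1N1CCN(c2ccccc2)CC1)c1ccc(NS(C)(=O)=O)c(F)c1` gives 0.8 nM, the lowest of the three numbers; compound 1 is the nearest to it and compound 2 the furthest, both beyond the scatter. Going by the values given here, the one measured step, a 1.4-fold higher number from compound 1 to compound 2 (0.14 log units; within the scatter), concerns a different exchange and bears only loosely on the move to compound 4 `CC(C)COc1cc(C(C)(C)C)ccc1CNC(=O)C(C)c1ccc(NS(C)(=O)=O)c(F)c1`, which carries isobutoxy in place of 4-phenylpiperazin-1-yl on an aromatic carbon, placed on an aromatic carbon ortho to a large group and meta to a tert-butyl group. Among the compounds with values here, no measured step covers this exchange directly; the nearest guide is that compounds 1 and 2, which carry small chain groups at the corresponding place, sit above compound 3. A step of about a 3.8-fold higher number from compound 3 to compound 4 (0.57 log units; beyond the scatter) in this assay is therefore expected, toward a higher number. Compound 4 is estimated at 3 nM in this assay, within 1 nM to 9 nM.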

Compound 4, inhibition constant: 2.1 nM
Beside the measured number, compound 4's estimate is 1.4-fold (0.15 log units) above it; the measured number falls inside the stated range.
By their numbers in this assay, from the lowest: compound 3; then compounds 4, 1 and 2 (each within the scatter of the next).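

In this assay, the exchange of 4-phenylpiperazin-1-yl for isobutoxy gives a 2.6-fold higher number from compound 3 to compound 4 (0.42 log units; beyond the scatter). This shows that the aromatic carbon ortho to a large group and meta to a tert-butyl group accepts a chain with no ring in place of the two-ring group, at a modest cost in this read-out. Nothing available explains the size of this step.

Open, on these data alone, is whether piperazin-1-yl without its phenyl ring, or a simple amine such as dimethylamino, would match compound 3 at this place.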